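A Methyl Step Repeated on a Second Core

The compounds below may be only part of what the source reports. "The series", "measured", "known", "first", "only" and "open" are said of these compounds alone.

Three compounds were measured in a functional assay on A549 cells (Homo sapiens) for cytotoxicity, read by MTT assay, with a stated time of 24 h; on this read-out higher numbers stand for weaker inhibition and lower numbers for stronger inhibition. In this assay compound 1 `Cc1ncc([N+](=O)[O-])n1CCOc1ccc(F)cc1` gives 129 ug/mL. Compound 2 `Cc1cc(OCCn2c([N+](=O)[O-])cnc2C)ccc1F` differs from compound 1 by methyl in place of hydrogen on an aromatic carbon, and in this assay compound 2 gives 226 ug/mL. That change produced a 1.8-fold higher number from compound 1 to compound 2 (0.24 log units; within the scatter), so the two values cannot be told apart. Compound 3 `Cc1ncc([N+](=O)[O-])n1CCn1ccnc1` rests on a different core; how it differs from compound 1 is not broken down here. In this assay compound 3 gives 240 ug/mL, and the gap between compound 3 and compound 2 also lies within the scatter.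

Compound 4 `Cc1nccn1CCn1c([N+](=O)[O-])cnc1C` is not yet measured. It differs from compound 3 by methyl in place of hydrogen on an aromatic carbon. This is the same kind of change as that from compound 1 to compound 2, but not the same one: in the earlier case the methyl enters on a six-membered aromatic ring of carbon only, ortho to a fluoro group and meta to a large group, whereas here it enters on a five-membered aromatic ring with 2 nitrogen, between two ring nitrogen atoms, next to the ring atom that bears a large group.

Going by the values given here, the step from compound 3 to compound 4 in this assay is expected to be a 1.2-fold higher number from compound 3 to compound 4 (0.08 log units; within the scatter), a small move in the direction of the earlier methyl step, because the only guide is a 1.8-fold higher number from compound 1 to compound 2 (0.24 log units; within the scatter) and that step stayed within the scatter. On that basis compound 4 is estimated at 290 ug/mL, with a likely range from 150 ug/mL to 560 ug/mL.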

Compound 4, half-maximal inhibitory concentration: 195 ug/mL
For compound 4 the middle estimate is 1.5-fold (0.17 log units) above the measured one; measured number inside the range.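

In this assay, methyl in place of hydrogen on an aromatic carbon gave a 1.2-fold lower number from compound 3 to compound 4 (0.09 log units; within the scatter), so on this core, as on the core of compound 1, the effect of the change cannot be separated from the usual spread of repeated measurements. Set side by side, the two steps cannot be told apart: the same change on two cores in this assay, a 1.8-fold higher number (0.24 log units; within the scatter) from compound 1 to compound 2 and a 1.2-fold lower number (0.09 log units; within the scatter) from compound 3 to compound 4, 2.2-fold (0.33 log units) apart, within the scatter of two such steps. This shows that, in these two pairs, the change stayed within the scatter on both cores and gave no sign of depending on the core, but it does not show that the step has a fixed size or direction, since the two pairs are few, the methyl enters at a different kind of place in each, and a small real difference between them could lie hidden in the scatter.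

The compounds shown leave open whether a group other than methyl, such as ethyl, an amine or a carboxylic acid, would give a step beyond the scatter on either core. They also leave open whether the same methyl step would stay as small on a further core, for instance one in which a longer chain joins the two ring systems.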